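The source may report more compounds than this note shows. Statements on the series, on what has been measured and on what is new or still open speak of the compounds shown alone.

Three analogues of the shared core have been run through a functional assay on MDA-MB-231 cells (Homo sapiens) for cytotoxicity, read by MTT assay, with a stated time of 48 h; on this read-out lower numbers stand for stronger inhibition and higher numbers for weaker inhibition. For the measured compounds named here, compound 1 `Cc1ccc2nc(Cl)c(/C=N/n3cc(-c4ccccc4)nc3N)cc2c1` gives 48100 nM and compound 2 `Cc1ccc2nc(Cl)c(/C=N/n3cc(-c4ccc(Cl)cc4)nc3N)cc2c1` gives 35200 nM; the only measured single change between them is a 1.4-fold lower number from compound 1 to compound 2 (0.14 log units; within the scatter). Compound 3 `Nc1nc(-c2cccc3ccccc23)cn1/N=C/c1cc2ccccc2nc1Cl` stands apart: in this assay compound 3 returns only a limit, > 50000 nM, which is the limit of > 50000 nM in this assay, at which 1 of the 3 values shown sits. Compound 4 `Cc1ccc2nc(Cl)c(/C=N/n3cc(-c4cccc5ccccc45)nc3N)cc2c1` differs from compound 3 by methyl in place of hydrogen on an aromatic carbon. No measured step covers that change; the one step available, a 1.4-fold lower number from compound 1 to compound 2 (0.14 log units; within the scatter), was within the scatter, and compounds 1 and 2, which already carry the methyl, both sit at the weak end of the numbers shown. For compound 4 the expected step is a number no higher from compound 3 to compound 4 (the limit leaves the size open), with an estimate of 50000 nM (range 25000 nM to 100000 nM), and a limit rather than a number is expected to remain likely.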

Compound 4, half-maximal inhibitory concentration: > 50000 nM
Compound 4 gave a limit, no number (the forecaster's own chance of this, stated with the estimate: 55%); the middle value lies on the limit itself.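

Methyl on this aromatic carbon of the fused system leaves the naphthalen-1-yl pair at a limit, so the step between compound 3 and compound 4 cannot be read: the limit of > 50000 nM in this assay, at which 2 of the 4 values shown sit.

Naphthalen-1-yl in place of 4-chlorophenyl gives an at least 1.4-fold higher number from compound 2 to compound 4 (0.15 log units; that floor lies within the scatter), and naphthalen-1-yl in place of phenyl gives an at least 1.0-fold higher number from compound 1 to compound 4 (0.01 log units; that floor lies within the scatter). Neither swap is therefore shown to change the read-out.

The compounds shown leave open what methyl does with phenyl or 4-chlorophenyl in that place. They also leave open whether an amine or a carboxylic acid on this carbon would give a number under the limit.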